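The source may hold more compounds than are shown below. What is called first, only, known or untested is meant among the compounds shown, and "the series" means these compounds.

Compound 1 `CCN1CCN(C(=S)SCC(=O)N(Cc2ccc(OC)cc2)c2cc(OC)c(OC)c(OC)c2)CC1`, compound 2 `COc1ccc(CN(C(=O)CSC(=S)N2CCN(C(C)=O)CC2)c2cc(OC)c(OC)c(OC)c2)cc1` and compound 3 `COc1ccc(CN(C(=O)CSC(=S)N2CCc3ccccc32)c2cc(OC)c(OC)c(OC)c2)cc1` share one core and differ only in the group on the thiocarbonyl carbon. In a functional assay on MGC-803 cells (Homo sapiens) for inhibition, read by CCK-8 assay, with a stated time of 48 h (a higher number here means a weaker inhibitor, a lower number a stronger inhibitor), compound 1 gives 9890 nM, compound 2 gives 480 nM and compound 3 gives 8410 nM. Compound 3 thus holds the second highest of the three numbers: the step of a 1.2-fold lower number from compound 1 to compound 3 (0.07 log units; within the scatter) leaves compound 3 alongside compound 1, whereas the step of an 18-fold higher number from compound 2 to compound 3 (1.24 log units; beyond the scatter) sets compound 3 far from compound 2. Compound 4 `COc1ccc(CN(C(=O)CSC(=S)N2CCCc3cc(C)ccc32)c2cc(OC)c(OC)c(OC)c2)cc1` is not yet measured and differs from compound 3 in one place: 6-methyl-1,2,3,4-tetrahydroquinolin-1-yl in place of 2,3-dihydro-1H-indol-1-yl on a thiocarbonyl carbon. Within the data shown here, both measured steps that end at compound 3 alter the group on the thiocarbonyl carbon, yet neither involves 6-methyl-1,2,3,4-tetrahydroquinolin-1-yl, and the only large step, an 18-fold higher number from compound 2 to compound 3 (1.24 log units; beyond the scatter), turns on 4-acetylpiperazin-1-yl, which neither compound 3 nor compound 4 carries. Nothing measured shows that exchanging 2,3-dihydro-1H-indol-1-yl for 6-methyl-1,2,3,4-tetrahydroquinolin-1-yl matters, so for compound 4 a step within the scatter is expected, a 1.1-fold lower number from compound 3 to compound 4 (0.02 log units; within the scatter). Compound 4 is therefore expected near 8000 nM in this assay, with a range from 3000 nM to 22000 nM.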

Compound 4, half-maximal inhibitory concentration: 6490 nM
Compound 4: middle estimate off by 1.2-fold (0.09 log units), on the high side, and the stated range covers the measured number.
By their numbers in this assay, from the lowest: compound 2; then compounds 4, 3 and 1 (each within the scatter of the next).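

In this assay, a six-membered non-aromatic ring carrying a methyl group on the thiocarbonyl carbon reads no differently from the five-membered ring of 2,3-dihydro-1H-indol-1-yl, with a 1.3-fold lower number from compound 3 to compound 4 (0.11 log units; within the scatter) as the step. The same holds against 4-ethylpiperazin-1-yl, with a 1.5-fold lower number from compound 1 to compound 4 (0.18 log units; within the scatter) as the step, whereas a 14-fold higher number from compound 2 to compound 4 (1.13 log units; beyond the scatter) shows that a second group on this carbon also stays far from 4-acetylpiperazin-1-yl, leaving compound 2 alone among the four. No available measurement gives a reason for these steps.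

Ring size and the methyl group change together here, so the separate contribution of each remains open; the unsubstituted 1,2,3,4-tetrahydroquinolin-1-yl group would separate them. Also open, going by these compounds, is whether the acetyl group itself matters, or whether a propanoyl or methoxycarbonyl group on the piperazine would read alike.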